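The source may report more compounds than this note shows. Statements on the series, on what has been measured and on what is new or still open speak of the compounds shown alone.

Measured so far:
compound 1 `O=C1/C(=C/c2cccc(F)c2)Cc2cc(O)ccc21` gives 458 nM
compound 2 `O=C1/C(=C/c2ccc(F)cc2)Cc2cc(O)ccc21` gives 679 nM
compound 3 `N#Cc1cccc(/C=C2\Cc3cc(O)ccc3C2=O)c1` gives 444 nM

All three numbers come from an assay on isolated protein for inhibition of Amine oxidase [flavin-containing] A (Homo sapiens), read by fluorescence and spectrophotometry, with a stated time of 20 min; a lower number here means a stronger inhibitor, a higher number a weaker inhibitor. Compound 1 and compound 3 differ in one place, (cyano in place of fluoro on an aromatic carbon), and the step is a 1.0-fold lower number from compound 1 to compound 3 (0.01 log units; within the scatter). Compound 2 has the same atoms as compound 1 joined differently; the difference between the two cores is not broken down here, and their two values lie within the scatter of each other, as do those of compound 2 and compound 3.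

Compound 4 `N#Cc1ccc(/C=C2\Cc3cc(O)ccc3C2=O)cc1` has not yet been measured in this assay. It differs from compound 2 by cyano in place of fluoro on an aromatic carbon, the same kind of change as that from compound 1 to compound 3, though the place is not identical: in compound 3 the cyano sits meta to a large group, in compound 4 para to a large group. Because a 1.0-fold lower number from compound 1 to compound 3 (0.01 log units; within the scatter) was flat, the expected step is a 1.0-fold lower number from compound 2 to compound 4 (0.02 log units; within the scatter). Compound 4 is therefore estimated at 650 nM, between 300 nM and 1400 nM.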

Compound 4, half-maximal inhibitory concentration: 2080 nM
Compound 4: the middle estimate sits 3.2-fold (0.51 log units) below what was measured, and the stated range ends below it.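

In this assay, cyano in place of fluoro on an aromatic carbon, here para to a large group, gives a 3.1-fold higher number from compound 2 to compound 4 (0.49 log units; beyond the scatter). Set beside the earlier case, this shows that the same change did not carry over unaltered from one core to the other in this series: the same change on two cores in this assay, a 1.0-fold lower number (0.01 log units; within the scatter) from compound 1 to compound 3 and a 3.1-fold higher number (0.49 log units; beyond the scatter) from compound 2 to compound 4, 3.2-fold (0.50 log units) apart, beyond the scatter of two such steps

The comparison rests on a single pair of steps, so it shows that the outcome of this change depends on the core it is made on, but it does not show why, and it offers no rule for predicting the step on any further core.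

The compounds shown carry only fluoro or cyano on this aromatic ring, so it remains open whether a methoxy group, a trifluoromethyl group, an amine or a carboxylic acid would follow the flat step or the larger one. Going by these compounds, it also remains open how either core would respond to a change elsewhere, such as replacing the hydroxyl group with a methoxy group.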